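A few compounds are considered here, and "the series" means these few. Any claim that something is new, unique, unknown or untested is made for them only; others in the source may bear on it.

Measured so far in an ADME assay on HEK-293T cells (Homo sapiens) for cytotoxicity, read by MTT assay, with a stated time of 3 days; on this read-out lower numbers stand for higher toxicity in this test and higher numbers for lower toxicity in this test:
Compound 1 `CC(C)OC(=O)COC(=O)c1ccc([N+](=O)[O-])o1` gives > 100000 nM, a limit of the assay and not a number.
Compound 2 `CCC(C)(C)NC(=O)COC(=O)c1ccc([N+](=O)[O-])o1` gives > 100000 nM, also a limit.
Compound 3 `CC(C)(C)N(CCCc1ccccc1)C(=O)COC(=O)c1ccc([N+](=O)[O-])o1` is reported only as "not active" (no number reported), with no number.

Compound 3 thus stands without a figure in this assay; the two further values shown are limits, and the limit of > 100000 nM in this assay, at which 2 of the 3 values shown sit, is where two of the three values sit. For the measured compounds named here, the single computed step, a step that the two limits leave unreadable from compound 1 to compound 2, runs between two limits and its size cannot be read. Compound 4 `CC(C)(C)N(Cc1ccccc1C(F)(F)F)C(=O)COC(=O)c1ccc([N+](=O)[O-])o1` differs from compound 3 by 2-(trifluoromethyl)phenyl in place of phenethyl on a saturated chain carbon bound to an amide-type nitrogen. Going by the values given here, no measured step bears on this change, and the only recorded step is unreadable, so nothing beyond the scatter is expected in this assay, and a limit rather than a number is the likelier outcome. Compound 4 is expected to give about 100000 nM, within 40000 nM to 250000 nM.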

Compound 4, half-maximal cytotoxic concentration: 65000 nM
The estimate for compound 4 lay 1.5-fold (0.19 log units) above the measured number, within the range that was stated.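

No new step can be read from compound 3 to compound 4: compound 3 carries no number, while compound 4 gives 65000 nM. The compounds shown leave open what size of change 2-(trifluoromethyl)phenyl in place of phenethyl brings.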